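The source may report more compounds than this note shows. Statements on the series, on what has been measured and on what is new or still open speak of the compounds shown alone.

Compound 1, `Cc1cccc(-c2nc3cc(C)ccc3c(=O)[nH]2)c1`, was tested in a functional assay on T47D cells (Homo sapiens) for cytotoxicity, read by MTT assay, with a stated time of 2 days; on this read-out higher numbers stand for weaker inhibition and lower numbers for stronger inhibition. In this assay compound 1 gives > 50000 nM, which is a limit of the assay and not a number. Compound 2, `O=c1[nH]c(-c2cccc3ccccc23)nc2ccc(N3CCCCC3)cc12`, gives > 50000 nM, again a limit. Compound 3, `Cc1ccc2nc(-c3cccc(F)c3)[nH]c(=O)c2c1`, gives > 50000 nM, and this too is a limit. All three compounds thus stand at the limit of > 50000 nM in this assay, at which 3 of the 3 values shown sit, so no measured number separates them, and compound 1 has no rank of its own among them.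

Compound 4, `Cc1ccc2c(=O)[nH]c(-c3cccc(C(F)(F)F)c3)nc2c1`, has not yet been measured. It differs from compound 1 by trifluoromethyl in place of methyl on an aromatic carbon, on a six-membered aromatic ring of carbon only, meta to a large group. Going by the values given here, no two measured compounds differ in one place only, so the data hold no direct measure of a change of this kind. The expectation therefore rests on compound 1 and its limit of > 50000 nM. The estimated step of a number no higher from compound 1 to compound 4 (the limit leaves the size open) is expected to stay within the usual scatter, and the assay will probably report only a limit again. The estimate for compound 4 is 50000 nM, with an expected range of 20000 nM to 100000 nM.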

Compound 4, half-maximal inhibitory concentration: > 50000 nM
Compound 4 ended at the assay's limit; the forecaster's own chance of this, stated with the estimate: 80%; the middle value lies on the limit itself.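

In this assay, going by these compounds alone, compound 1 and compound 4 both stand at a limit of the assay and not at a number, so no step between them can be read. All the compounds shown share that one limit: the limit of > 50000 nM in this assay, at which 4 of the 4 values shown sit. They leave open whether any change to the core of compound 1 would give a readable value, and how large the change from methyl to trifluoromethyl is.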